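The compounds below may be only part of what the source reports. "The series", "measured", "known", "first", "only" and "open" are said of these compounds alone.

Of the compounds shown here, two have so far been measured in a functional assay on HEK293 cells for positive allosteric modulation of metabotropic glutamate receptor 5 (Homo sapiens), read by FLIPR and calcium flux; a lower number here means that less compound is needed, a higher number that more compound is needed for the effect. Compound 1 `O=C(COCc1ccncc1)N1CCN(c2cc(Cl)ccn2)CC1` gives 4200 nM. Compound 2 `O=C(COCc1cnccn1)N1CCN(c2ccc(Cl)cc2Cl)CC1` gives 5200 nM in this assay, the larger of the two numbers, though its gap to compound 1 lies within the usual scatter of repeated measurements, so the two cannot be told apart. Compound 3 `O=C(COCc1nccs1)N1CCN(c2ccc(Cl)cc2Cl)CC1` shares the core of compound 2 and differs from it in a single place: 1,3-thiazol-2-yl in place of pyrazin-2-yl on a saturated chain carbon bound to an oxygen on a saturated carbon. Among the measured compounds shown here, no measured pair shows this kind of exchange, so there is nothing to read its size from directly. Because compound 1 gives 4200 nM and compound 2 gives 5200 nM in this assay, two numbers that sit within the usual scatter of each other despite the compounds differing in two places, the expectation for compound 3 is a step no larger than the scatter, with no clear direction. Compound 3 is therefore estimated at 4500 nM, within a range from 1500 nM to 13000 nM. This estimate means a step of a 1.2-fold lower number from compound 2 to compound 3 (0.06 log units; within the scatter), expected to stay within the usual scatter.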

Compound 3, half-maximal effective concentration: 10300 nM
For compound 3 the middle estimate is 2.3-fold (0.36 log units) below the measured one; the measured number falls inside the stated range.
By their numbers in this assay, from the lowest: compounds 1, 2 and 3 (each within the scatter of the next, the first and the last beyond it).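

Among the compounds shown here, the exchange of pyrazin-2-yl for 1,3-thiazol-2-yl gives the first comparison that changes only one place, and in this assay it produces a 2.0-fold higher number from compound 2 to compound 3 (0.30 log units; within the scatter), so the two compounds cannot be told apart. On a saturated chain carbon bound to an oxygen on a saturated carbon, a five-membered aromatic ring containing sulfur can therefore stand in for a six-membered aromatic ring without a step beyond the scatter. Nothing shown here offers a measured explanation for the size of this step.

Still open, as far as these compounds go, is how this position responds to a group of a different kind, such as a plain phenyl ring, a morpholine or a carboxylic acid. Also open, from the compounds shown here alone, is whether 1,3-thiazol-2-yl gives a similar result on the core of compound 1.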